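Replacing dimethylamino with hydrogen on the shared core

This account rests on a few compounds, and the source may have more. Where it says the series, first, only, none or still open, it means among the compounds named here.

Measured compounds:
compound 1 `N#CC1=C(N)OC(c2c[nH]c3ccccc23)=C(C#N)C1c1ccccc1F`: "not active" (no number reported)
compound 2 `COc1cc(Br)c(C2C(C#N)=C(N)OC(c3c[nH]c4ccccc34)=C2C#N)cc1OC`: 20.5%
compound 3 `CN(C)c1ccc(C2C(C#N)=C(N)OC(c3c[nH]c4ccccc34)=C2C#N)cc1`: 18.5%

In a functional assay, tested at 100 ug/mL (a lower number here means a weaker effect, a higher number a stronger effect of the compound at the concentration tested), compound 1 is reported as "not active" (no number reported) without a number. Compound 2 gives 20.5% and compound 3 gives 18.5% in this assay; the two values lie within the usual scatter of each other, so neither can be called stronger. Compound 4 `N#CC1=C(N)OC(c2c[nH]c3ccccc23)=C(C#N)C1c1ccccc1` has not yet been measured. It differs from compound 3 by hydrogen in place of dimethylamino on an aromatic carbon. Compound 1, which also lacks dimethylamino at that place, is reported without activity, so a modest drop is expected for compound 4, a step of a number 7.5 percentage points lower from compound 3 to compound 4 (within the scatter) that may not exceed the scatter. Compound 4 is estimated at 11%, within 0% to 24%.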

Compound 4, a percentage reported as activity, at one concentration (the size of the read-out at that concentration, not a potency): 19.3%
Compound 4: the middle estimate sits 8.3 percentage points below what was measured; measured number inside the range.
By their numbers in this assay, from the lowest: compounds 3, 4 and 2 (each within the scatter of the next).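

In this assay, going from 4-(dimethylamino)phenyl to phenyl gives a number 0.8 percentage points higher from compound 3 to compound 4 (within the scatter), so the dimethylamino group is not needed at this place for the read-out seen. Compound 4 still gives a number, so the lack of dimethylamino alone cannot account for compound 1 being reported as "not active" (no number reported). No measurement here explains why this place tolerates the change.

From the compounds shown here alone, it remains open whether another group at this place, such as a carboxylic acid or a primary amine, would move the read-out beyond the scatter.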